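Swapping methyl for fluoro on the outer ring

The compounds below may be only part of what the source reports. "The series", "measured", "known", "first", "only" and "open" are said of these compounds alone.

Measured so far:
compound 1, `Cc1ccc(-c2ccc(F)cc2)n1-c1ccc(-c2nc3ccccc3s2)cc1`, 11800 nM
compound 2, `Cc1ccc(-c2ccc(F)cc2)n1-c1ccc(-c2nc3ccc(F)cc3s2)cc1`, 14100 nM
compound 3, `COc1ccc2nc(-c3ccc(-n4c(C)ccc4-c4ccc(C)cc4)cc3)sc2c1`, 20500 nM

All three were tested in a functional assay on MDA-MB-231 cells (Homo sapiens) for cytotoxicity, read by MTT assay, with a stated time of 72 h; a higher number here means a weaker inhibitor, a lower number a stronger inhibitor. Compound 3 gives the highest number of the three, yet its gap to compound 2 and to compound 1 is within the scatter, so no order among them can be claimed. Compound 4, `COc1ccc2nc(-c3ccc(-n4c(C)ccc4-c4ccc(F)cc4)cc3)sc2c1`, differs from compound 3 by fluoro in place of methyl on an aromatic carbon. For the measured compounds named here, the only measured step of a related kind, a 1.2-fold higher number from compound 1 to compound 2 (0.08 log units; within the scatter), put a fluoro on a different ring and stayed within the scatter. Nothing here points to a shift either way, so the expected step of a 1.0-fold lower number from compound 3 to compound 4 (0.01 log units; within the scatter) is small. Compound 4 is therefore estimated at 20000 nM, between 8000 nM and 50000 nM.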

Compound 4, half-maximal inhibitory concentration: 13800 nM
The estimate for compound 4 lay 1.4-fold (0.16 log units) above the measured number; measured number inside the range.
By their numbers in this assay, from the lowest: compounds 1, 4, 2 and 3 (each within the scatter of the next).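

Changing 4-methylphenyl to 4-fluorophenyl on the outer ring (a 1.5-fold lower number from compound 3 to compound 4 (0.17 log units; within the scatter)) in this assay shows that this position, too, has so far given no step beyond the scatter. With this change, the methoxy compound also sits within the scatter of the fluoro compound (a 1.0-fold lower number from compound 2 to compound 4 (0.01 log units; within the scatter)) and the hydrogen compound (a 1.2-fold higher number from compound 1 to compound 4 (0.07 log units; within the scatter)), so swapping either of these groups for methoxy on the core shows no clear effect. No measured evidence bears on the reason for these results. Still open, as far as these compounds go, is whether an amine or a carboxylic acid at the outer-ring position would move the number beyond the scatter.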